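Sulfonyl aryl exchange from compound 3 to compound 4

The source may report more compounds than this note shows. Statements on the series, on what has been measured and on what is new or still open speak of the compounds shown alone.

Measured so far in a functional assay on RS4-11 cells (Homo sapiens) for inhibition, read by CCK-8 assay, with a stated time of 48 h, tested at 20 uM (on this read-out higher numbers stand for more inhibition of growth at the one concentration tested and lower numbers for less inhibition of growth), for three compounds:
compound 1 `Cc1ccc(S(=O)(=O)Oc2ccccc2/C=C(\C#N)C(=O)Nc2nnc(Cc3cccc4ccccc34)s2)cc1` gives 73%
compound 2 `N#C/C(=C\c1ccccc1OS(=O)(=O)c1ccccc1[N+](=O)[O-])C(=O)Nc1nnc(Cc2ccccc2)s1` gives 71%
compound 3 `Cc1ccc(S(=O)(=O)Oc2ccccc2/C=C(\C#N)C(=O)Nc2nnc(Cc3ccc(F)cc3)s2)cc1` gives 72%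

Compound 3 at 72% lies within the scatter of both compound 1 and compound 2, and the three values cannot be told apart. Compound 4 `N#C/C(=C\c1ccccc1OS(=O)(=O)c1ccccc1[N+](=O)[O-])C(=O)Nc1nnc(Cc2ccc(F)cc2)s1` has not been measured and differs from compound 3 by 2-nitrophenyl in place of 4-methylphenyl on a sulfonyl sulfur which in words is 2-nitrophenyl in place of 4-methylphenyl on a sulfonyl sulfur. Among the compounds with values here, no measured step changes that group. Within the data shown here, the only measured step is a number 1 percentage points lower from compound 1 to compound 3 (within the scatter) and it sits at another place, so it bears on this change only indirectly. Compound 2 also carries 2-nitrophenyl on a sulfonyl sulfur, and its 71% stays within the scatter of compound 3. No step beyond the scatter is therefore expected, and the estimated change is no change at the digits printed from compound 3 to compound 4 (within the scatter) on this evidence. Compound 4 is expected at 72% with an estimated range of 62% to 82% in this assay when tested.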

Compound 4, percent growth inhibition at one concentration: 61%
For compound 4 the middle estimate is 11 percentage points above the measured one, and the stated range ends above it.
By their numbers in this assay, from the lowest: compounds 4, 2, 3 and 1 (each within the scatter of the next, the first and the last beyond it).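

In this assay, within the data shown here, the sulfonyl sulfur is the first place where a single exchange goes beyond the scatter: 2-nitrophenyl in place of 4-methylphenyl gives a number 11 percentage points lower from compound 3 to compound 4 (beyond the scatter). The other exchange involving compound 4, with 2-nitrophenyl kept on the sulfonyl sulfur, puts fluoro in place of hydrogen on an aromatic carbon and gives a number 10 percentage points lower from compound 2 to compound 4 (within the scatter), so like the earlier change at that end of the molecule it stays within the scatter. Nothing at hand accounts for the lower number at the sulfonyl position.

On these data alone, whether the same exchange has a step of similar size on the naphthalen-1-yl background of compound 1 remains open. Also open, as far as these compounds go, is how a plain phenyl, or a phenyl carrying an amine or a carboxylic acid, would read on the sulfonyl sulfur.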